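Cytotoxicity notes: step from compound 2 to compound 3

The source may report more compounds than this note shows. Statements on the series, on what has been measured and on what is new or still open speak of the compounds shown alone.

Measured compounds:
compound 1, `Cc1cc(/C=C2\SC(=S)N(c3ccccc3)C2=O)c(C)n1-c1ccc(O)c(C(=O)O)c1`: > 100000 nM
compound 2, `Cc1cc(/C=C2\SC(=S)N(Cc3ccc(Br)cc3)C2=O)c(C)n1-c1ccc(O)c(C(=O)O)c1`: 94400 nM

In an ADME assay on MT2 cells (Homo sapiens) for cytotoxicity, read by XTT assay, with a stated time of 4 days (on this read-out lower numbers stand for higher toxicity in this test and higher numbers for lower toxicity in this test), compound 1 reaches only a limit, > 100000 nM. Within the data shown here, compound 2 gives 94400 nM in this assay, the only actual number in the set. Among the measured compounds shown here, the single measured step is an at least 1.0-fold lower number from compound 1 to compound 2 (0.02 log units; that floor lies within the scatter), 4-bromobenzyl in place of phenyl on an amide-type nitrogen in a ring, and it shows no movement beyond the scatter.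

Compound 3, `COC(=O)c1ccc(CN2C(=O)/C(=C/c3cc(C)n(-c4ccc(O)c(C(=O)O)c4)c3C)SC2=S)cc1`, differs from compound 2 by methoxycarbonyl in place of bromo on an aromatic carbon; the place is an aromatic carbon of the benzyl ring, para to a large group. For the measured compounds named here, no measured step changes a substituent on that ring, so the one step at hand bears on this change only indirectly: it shows that a large change at the ring nitrogen left the read-out essentially unchanged, and compound 1 sits at the limit of > 100000 nM in this assay, at which 1 of the 2 values shown sits.

For compound 3 the expected step of a 1.0-fold lower number from compound 2 to compound 3 (0.02 log units; within the scatter) is therefore none beyond the scatter. Compound 3 is estimated at 90000 nM, within 30000 nM to 300000 nM, with a fair chance that only a limit is reported.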

Compound 3, half-maximal cytotoxic concentration: 36900 nM
For compound 3 the middle estimate is 2.4-fold (0.39 log units) above the measured one; the measured number falls inside the stated range.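

In this assay, among these compounds, the aromatic carbon of the benzyl ring, para to a large group, is the first place where a change moves the read-out beyond the scatter: methoxycarbonyl in place of bromo gives a 2.6-fold lower number from compound 2 to compound 3 (0.41 log units; beyond the scatter), so on this read-out compound 3 shows higher toxicity in this test than compound 2. The change at the ring nitrogen, which gave no movement beyond the scatter with the 4-bromobenzyl group, reads differently with the 4-(methoxycarbonyl)benzyl group, giving an at least 2.7-fold lower number from compound 1 to compound 3 (0.43 log units; beyond the scatter). That step is only a floor, since the entry for compound 1 is a limit and not a number: the limit of > 100000 nM in this assay, at which 1 of the 3 values shown sits.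

A single exchange on the benzyl ring cannot show whether the shift belongs to methoxycarbonyl alone or would also appear with an amine or a nitrile at the same place. Going by these compounds, it also remains open how the read-out responds when the benzyl group on the ring nitrogen gives way to a longer chain bearing the same methoxycarbonyl group.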